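A few compounds are considered here, and "the series" means these few. Any claim that something is new, unique, unknown or untested is made for them only; others in the source may bear on it.

In a functional assay on MCF7 cells (Homo sapiens) for cytotoxicity, read by MTT assay, with a stated time of 48 h (on this read-out higher numbers stand for weaker inhibition and lower numbers for stronger inhibition), compound 1 (`COc1ccc(-c2nc3ccccn3c2C(=O)/C=C\Nc2ccc3[nH]ccc3c2)cc1`) gives 18900 nM, compound 2 (`O=C(/C=C\Nc1cnc2ccccc2c1)c1c(-c2ccccc2)nc2ccccn12`) gives 5170 nM, and compound 3 (`O=C(/C=C\Nc1ccc2[nH]ccc2c1)c1c(-c2ccc(Cl)cc2)nc2ccccn12`) gives 7130 nM. Compound 3 lies within the scatter of compound 2 and clearly below compound 1. Compound 4 (`O=C(/C=C\Nc1ccc2ncccc2c1)c1c(-c2ccc(Cl)cc2)nc2ccccn12`) follows from compound 3 by one change: quinolin-6-yl in place of 1H-indol-5-yl on an amine nitrogen. Among the measured compounds shown here, the single measured step, a 2.7-fold lower number from compound 1 to compound 3 (0.42 log units; beyond the scatter), is chloro in place of methoxy on an aromatic carbon and leaves the group on the amine nitrogen untouched. For the measured compounds named here, no measured step therefore speaks directly to this change, and no shift beyond the scatter is expected in this assay. The expected step is a 1.1-fold lower number from compound 3 to compound 4 (0.04 log units; within the scatter). Compound 4 is estimated at 6500 nM, with an expected range of 2800 nM to 15000 nM.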

Compound 4, half-maximal inhibitory concentration: 22800 nM
The estimate for compound 4 lay 3.5-fold (0.55 log units) below the measured number; measured number above the stated range.
By their numbers in this assay, from the lowest: compounds 2 and 3 (each within the scatter of the next); then compounds 1 and 4 (each within the scatter of the next).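

In this assay, among the compounds shown here, the group on the amine nitrogen is not neutral: quinolin-6-yl in place of 1H-indol-5-yl gives a 3.2-fold higher number from compound 3 to compound 4 (0.50 log units; beyond the scatter) and is the first measured step at this position. The change swaps a hydrogen-bond donor for an acceptor and adds a heavy atom, and this single pair cannot separate those differences. Nothing available accounts for the step. On these data alone, it remains open whether the step holds with methoxy in place of chloro on the aromatic carbon. Also open, as far as these compounds go, is how a benzyl group on the amine nitrogen would read.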